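Working notes: from compound 1 to compound 3

This account rests on a few compounds, and the source may have more. Where it says the series, first, only, none or still open, it means among the compounds named here.

compound 1 `ClC(Cl)(Cl)c1nc(-c2ccccc2)c2ccccc2n1`: > 500000 nM (a limit)
compound 2 `FC(F)(F)c1cccc(-c2nc(C(Cl)(Cl)Cl)nc3ccccc23)c1`: > 500000 nM (a limit)

In an ADME assay on THP-1 cells (Homo sapiens) for cytotoxicity, read by MTT assay (on this read-out lower numbers stand for higher toxicity in this test and higher numbers for lower toxicity in this test), compound 1 gives > 500000 nM, which is a limit of the assay and not a number. Compound 1 therefore has no exact standing in the series. Compound 2 shares that position: the limit of > 500000 nM in this assay, at which 2 of the 2 values shown sit.

Compound 3 `COc1ccc(-c2nc(C(Cl)(Cl)Cl)nc3ccccc23)cc1` differs from compound 1 by one change: methoxy in place of hydrogen on an aromatic carbon. For the measured compounds named here, the only measured step that bears on it is another substitution on an aromatic carbon, a step that the two limits leave unreadable from compound 1 to compound 2. That step has no readable size, so it offers only weak guidance and fixes no direction. Compound 2 still reached a limit in this assay with > 500000 nM, and this is the sole reason to expect little movement here. No step beyond the usual scatter is therefore expected in this assay, and no direction is favoured. The expected change is a number no higher from compound 1 to compound 3 (the limit leaves the size open). For compound 3 the estimated value is 500000 nM, with an expected range from 200000 nM to 800000 nM, and a report as a limit is considered likely.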

Compound 3, concentration lethal to 50% of the cells: > 250000 nM
Compound 3 was reported as a limit (the forecaster's own chance of this, stated with the estimate: 70%); the middle value lies beyond the limit too.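

In this assay, for the compounds shown here, compound 1, compound 2 and compound 3 are all reported as limits, so no step among them can be read. The compounds shown leave open how far these three lie from one another, and whether trifluoromethyl or methoxy in place of hydrogen on an aromatic carbon moves the read-out at all.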